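Side-chain amine swap in the series: compound 2 to compound 3

A few compounds are considered here, and "the series" means these few. Any claim that something is new, unique, unknown or untested is made for them only; others in the source may bear on it.

Measured so far in a functional assay on HCT-116 cells (Homo sapiens) for inhibition; on this read-out higher numbers stand for weaker inhibition and lower numbers for stronger inhibition:
compound 1 `CCNC(=O)c1noc(-c2cc(C(C)C)c(O)cc2O)c1-c1cc(CN(C)C)no1`: 92 nM
compound 2 `CCNC(=O)c1noc(-c2cc(C(C)C)c(O)cc2O)c1-c1cc(CN2CCCC2)no1`: 51 nM

Compound 2 at 51 nM sits within the scatter of compound 1 at 92 nM on these numbers, so the two are not separated. The next structure is compound 3 `CCNC(=O)c1noc(-c2cc(C(C)C)c(O)cc2O)c1-c1cc(CN2CCN(C)CC2)no1`, which differs from compound 2 as follows: 4-methylpiperazin-1-yl in place of pyrrolidin-1-yl on a saturated chain carbon bound to an aromatic carbon. Among the compounds with values here, only one measured step bears on this change: a 1.8-fold lower number from compound 1 to compound 2 (0.26 log units; within the scatter), also a swap on the saturated chain carbon bound to an aromatic carbon. Within the data shown here, no measurement yet covers 4-methylpiperazin-1-yl, and that single step sets no firm direction. No shift beyond the scatter is therefore expected in this assay. The expected change is a 1.6-fold higher number from compound 2 to compound 3 (0.20 log units; within the scatter) as a working estimate. The estimate for compound 3 is 80 nM with an expected range of 35 nM to 180 nM.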

Compound 3, half-maximal inhibitory concentration: 340 nM
Beside the measured number, compound 3's estimate is 4.3-fold (0.63 log units) below it; the measured number lies above the stated range.
By their numbers in this assay, from the lowest: compounds 2 and 1 (each within the scatter of the next); then compound 3.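

The amine on the saturated chain carbon bound to an aromatic carbon is not a free choice in this assay: 4-methylpiperazin-1-yl gives a 6.7-fold higher number from compound 2 to compound 3 (0.82 log units; beyond the scatter) and a 3.7-fold higher number from compound 1 to compound 3 (0.57 log units; beyond the scatter). Within the data shown here, the earlier swap between dimethylamino and pyrrolidin-1-yl did not separate its two compounds, so this is the first change at the position to move the number beyond the scatter, and the move is towards weaker inhibition. Nothing available gives a measured property that would account for this step.

Still open, from the compounds shown here alone, is whether the weaker inhibition goes with the six-membered ring, the second ring nitrogen or the methyl on that nitrogen. Piperidin-1-yl, morpholin-4-yl and unsubstituted piperazin-1-yl on the same carbon would pull these three apart.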